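An Acetyl Group on an Aromatic Amine and Cytotoxicity

A few compounds are considered here, and "the series" means these few. Any claim that something is new, unique, unknown or untested is made for them only; others in the source may bear on it.

Measured so far:
Compound 1, `Nc1ccc(NC(=O)NCCCCC(c2ccc(F)cc2)c2ccc(F)cc2)cc1`, > 20000 nM
Compound 2, `CC(=O)Nc1ccc(NC(=O)NCCCCC(c2ccc(F)cc2)c2ccc(F)cc2)cc1`, > 20000 nM
Compound 3, `Nc1cc(NC(=O)NCCCCC(c2ccc(F)cc2)c2ccc(F)cc2)ccc1Cl`, 9240 nM

Of the compounds shown here, three have been tested in a functional assay on MDA-MB-231 cells (Homo sapiens) for cytotoxicity, read by MTT assay, with a stated time of 48 h; on this read-out higher numbers stand for weaker inhibition and lower numbers for stronger inhibition. Compound 1 gives > 20000 nM, which is a limit of the assay rather than a number. Compound 2 likewise gives > 20000 nM, again a limit. Among the measured compounds shown here, compound 3 is the only one with a number, 9240 nM.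

Compound 1 and compound 2 differ by acetyl in place of hydrogen on a nitrogen on an aromatic ring. The step is a step that the two limits leave unreadable from compound 1 to compound 2, since both sit at the limit of > 20000 nM in this assay, at which 2 of the 3 values shown sit. The cores of compound 1 and compound 3 differ by 3-amino-4-chlorophenyl in place of 4-aminophenyl on an amide-type nitrogen, a step of an at least 2.1-fold lower number from compound 1 to compound 3 (0.33 log units; beyond the scatter); from compound 2 the step is an at least 2.1-fold lower number from compound 2 to compound 3 (0.33 log units; beyond the scatter).

Compound 4, `CC(=O)Nc1cc(NC(=O)NCCCCC(c2ccc(F)cc2)c2ccc(F)cc2)ccc1Cl`, is not yet measured. It differs from compound 3 by acetyl in place of hydrogen on a nitrogen on an aromatic ring, the same change that carries compound 1 to compound 2, at a place described in the same words. That earlier step is unreadable, so the expectation for compound 4 rests only on compound 3 at 9240 nM and on the structural change itself. The expected step is a 1.4-fold higher number from compound 3 to compound 4 (0.15 log units; within the scatter). Compound 4 is estimated at 13000 nM, between 4500 nM and 35000 nM.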

Compound 4, half-maximal inhibitory concentration: 9120 nM
Compound 4: the middle estimate sits 1.4-fold (0.15 log units) above what was measured, within the range that was stated.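

In this assay acetyl in place of hydrogen on the nitrogen gives a 1.0-fold lower number from compound 3 to compound 4 (0.01 log units; within the scatter) and so on the core of compound 3 the two compounds cannot be told apart. The acetamido compound with the chloro group stands apart from the two compounds without it, with an at least 2.1-fold lower number from compound 2 to compound 4 (0.34 log units; beyond the scatter) and with an at least 2.1-fold lower number from compound 1 to compound 4 (0.34 log units; beyond the scatter) as well, but these steps do not say how acetyl acts on either core. The same change on the core of compound 1 cannot be read, so its carrying over from one core to another remains untested, since compound 1 and compound 2 each give a limit of the assay and not a number: the limit of > 20000 nM in this assay, at which 2 of the 4 values shown sit.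

The compounds shown leave open whether a propionyl or a methanesulfonyl group on the same nitrogen would read like acetyl on the core of compound 3. They also leave open how a methyl or a bromine in place of the chlorine would read with the amine or with the acetamido group.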